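Trimethoxy analogue of the dimethoxy hydrazide: growth inhibition note

The source may hold more compounds than are shown below. What is called first, only, known or untested is meant among the compounds shown, and "the series" means these compounds.

Among the compounds with values here, compound 1 `COc1ccc(C(=O)NNC(=O)c2ccc3[nH]c(-c4ccc([N+](=O)[O-])o4)nc3c2)cc1OC` is the only member of this set with a numeric reading in an ADME assay on Vero cells (Chlorocebus sabaeus) for inhibition, read by sulforhodamine B assay, with a stated time of 48 h; a higher number here means a weaker inhibitor of growth, a lower number a stronger inhibitor of growth; compound 1 gives 62.5 ug/mL. Compound 2 `COc1cccc(C(=O)NNC(=O)c2ccc3[nH]c(-c4ccc([N+](=O)[O-])s4)nc3c2)c1` stands at a limit of this assay: compound 2 gives > 250 ug/mL, a limit and not a number. That reading is the limit of > 250 ug/mL in this assay, at which 1 of the 2 values shown sits. Within the data shown here, no step between measured compounds is available, so nothing measured here tells what a change on the aromatic ring of the hydrazide does in this assay.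

Compound 3 `COc1cc(C(=O)NNC(=O)c2ccc3[nH]c(-c4ccc([N+](=O)[O-])o4)nc3c2)cc(OC)c1OC`, not yet measured, differs from compound 1 by methoxy in place of hydrogen on an aromatic carbon. The step from compound 1 to compound 3 is expected to stay within the usual scatter, or to lean slightly toward weaker inhibition, a 1.2-fold higher number from compound 1 to compound 3 (0.08 log units; within the scatter). Compound 3 is therefore expected to give about 75 ug/mL in this assay, with a likely range from 30 ug/mL to 180 ug/mL.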

Compound 3, concentration for 50% growth inhibition: 31.3 ug/mL
Compound 3: the middle estimate sits 2.4-fold (0.38 log units) above what was measured; low and high end bracket the measured number.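

On the six-membered aromatic ring of carbon only, methoxy in place of hydrogen on an aromatic carbon, ortho to a methoxy group and meta to a methoxy group, gives in this assay a 2.0-fold lower number from compound 1 to compound 3 (0.30 log units; within the scatter). Within the data shown here, this is the first measured step on this ring, and it shows that the position takes a methoxy group without a change beyond the scatter. Nothing measured in the series offers a reason for this step.

From the compounds shown here alone, whether this position also takes an amine, a carboxylic acid or a longer chain such as ethoxy stays open. Going by these compounds, compound 2 gives > 250 ug/mL, which is a limit and not a number, and it differs from the other compounds in more than one place, so what those differences do also stays open.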